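A few compounds are considered here, and "the series" means these few. Any claim that something is new, unique, unknown or untested is made for them only; others in the source may bear on it.

In a functional assay on HEp-2 cells (Homo sapiens) for cytotoxicity, read by MTT assay, with a stated time of 72 h, tested at 10 ug/mL (on this read-out higher numbers stand for more inhibition of growth at the one concentration tested and lower numbers for less inhibition of growth), compound 1 `O=C1NC(=S)/C(=C/c2ccc(Cl)cc2)S1` gives 22.3%. Compound 2 `O=C1NC(=S)/C(=C/c2cc(Cl)cc(Cl)c2Cl)S1` gives 23.5%, and compound 3 `O=C1NC(=S)/C(=C/c2ccccc2Br)S1` gives 21.2%. Compound 1 thus stands level with both of the others, since its distance to each lies within the scatter. Compound 4 `O=C1NC(=S)/C(=C/c2ccc(Br)cc2)S1` has not yet been measured, and it differs from compound 1 in one place: bromo in place of chloro on an aromatic carbon. Among the compounds with values here, no measured pair shows this exchange directly. Even so, no step beyond the scatter is expected in this assay, in either direction, as compound 3 gives 21.2% with a bromo group of its own. The expected change is a number 1.7 percentage points higher from compound 1 to compound 4 (within the scatter). The estimate for compound 4 is 24%, within an expected range of 13% to 38%.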

Compound 4, percent growth inhibition at one concentration: 18.2%
Beside the measured number, compound 4's estimate is 5.8 percentage points above it; measured number inside the range.
By their numbers in this assay, from the lowest: compounds 4, 3, 1 and 2 (each within the scatter of the next).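

In this assay, bromo in place of chloro on an aromatic carbon, para to a group of 8 heavy atoms, now has a direct reading: a number 4.1 percentage points lower from compound 1 to compound 4 (within the scatter). At this position, the two groups therefore cannot be told apart on this read-out. Nothing at hand offers an explanation for the result. The compounds shown leave open whether a group of another kind at this position, such as an amine or a carboxylic acid, would shift growth inhibition beyond the scatter.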